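Amino regioisomer on the aryl group of the dihydropyridine series

The compounds below may be only part of what the source reports. "The series", "measured", "known", "first", "only" and "open" are said of these compounds alone.

Measured so far:
compound 1, `COC(=O)C1=C(C)N=C(C)/C(=C(\O)OC)C1c1cccc([N+](C)(C)C)c1`, 50100 nM
compound 2, `C=Cc1ccccc1C1C(C(=O)OC)=C(C)N=C(C)/C1=C(\O)OC`, 4.47 nM
compound 3, `COC(=O)C1=C(C)N=C(C)/C(=C(\O)OC)C1c1ccccc1N`, 39800 nM

Compound 3 is `COC(=O)C1=C(C)N=C(C)/C(=C(\O)OC)C1c1ccccc1N` and in a functional assay (muscle tissue) with Cavia porcellus as the target (on this read-out higher numbers stand for an effect only at larger amounts of compound and lower numbers for an effect already at smaller amounts), compound 3 gives 39800 nM, the second highest of the three numbers. Its nearest neighbour is compound 1, whose value of 50100 nM lies within the scatter of that of compound 3, so no order between the two can be stated. Going by the values given here, compound 2 stands far apart; the step of an 8900-fold higher number from compound 2 to compound 3 (3.95 log units; beyond the scatter) is the only single-point change measured, and it shows how strongly the aryl substituent governs this read-out.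

Compound 4 is `COC(=O)C1=C(C)N=C(C)/C(=C(\O)OC)C1c1cccc(N)c1`. The change from compound 3 is 3-aminophenyl in place of 2-aminophenyl on a saturated ring carbon. Among the compounds with values here, no measured step bears directly on moving the amino group to the other ring position; the only related observation is that compound 1 and compound 3, which carry different groups at different ring positions, both give high numbers in this assay. The step of a 2.7-fold lower number from compound 3 to compound 4 (0.42 log units; beyond the scatter) is therefore expected to be small, with wide uncertainty in either direction. Compound 4 is estimated at 15000 nM, within a range of 2000 nM to 100000 nM.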

Compound 4, half-maximal effective concentration: 2000 nM
Compound 4: middle estimate off by 7.5-fold (0.88 log units), on the high side; measured number inside the range.
By their numbers in this assay, from the lowest: compound 2; then compound 4; then compounds 3 and 1 (each within the scatter of the next).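

Where the amino group sits on the aryl ring matters on its own: 3-aminophenyl in place of 2-aminophenyl on the saturated ring carbon gives a 20-fold lower number from compound 3 to compound 4 (1.30 log units; beyond the scatter) in this assay, although the atoms are unchanged. The better placement still does not close the distance to the vinyl series, with 3-aminophenyl in place of 2-vinylphenyl giving a 450-fold higher number from compound 2 to compound 4 (2.65 log units; beyond the scatter), while the amino group in place of the trimethylammonium group on the aromatic carbon gives a 25-fold lower number from compound 1 to compound 4 (1.40 log units; beyond the scatter). No measurement at hand offers a reason for these steps.

Open, from the compounds shown here alone, is whether a dimethylamino group or an acetamide in place of the amino group of compound 4 would shift the number further. Also open, going by these compounds, is whether a vinyl group on that same aromatic carbon would give a number as low as that of compound 2.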